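Trading 1-aminoethyl for acetamidomethyl when every reading is a limit

The source may hold more compounds than are shown below. What is called first, only, known or untested is meant among the compounds shown, and "the series" means these compounds.

In a physicochemical assay for solubility (on this read-out lower numbers stand for lower solubility and higher numbers for higher solubility), compound 1 (`Cc1c2c(n3c1CCN(C(=O)[C@H](C)N)CC[C@H](C)Nc1cc-3ccc1C(N)=O)CC(C)(C)CC2=O`) gives > 100 ug/mL as its result, which is a limit of the assay and not a number. Compound 2 (`Cc1c2c(n3c1CCCNC[C@H](C)Nc1cc-3ccc1C(N)=O)CC(C)(C)CC2=O`) gives > 100 ug/mL as its result, again a limit. Compound 3 (`COCCN1CC[C@H](C)Nc2cc(ccc2C(N)=O)-n2c(c(C)c3c2CC(C)(C)CC3=O)CC1=O`) gives > 100 ug/mL as its result, also a limit. The whole set therefore rests on a single reading (the limit of > 100 ug/mL in this assay, at which 3 of the 3 values shown sit), so compound 1 cannot be ranked against the other two.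

Compound 4 (`CC(=O)NCC(=O)N1CCc2c(C)c3c(n2-c2ccc(C(N)=O)c(c2)N[C@@H](C)CC1)CC(C)(C)CC3=O`) has not yet been measured. It keeps the core of compound 1 and changes one group on a carbonyl carbon, with acetamidomethyl in place of 1-aminoethyl (acetamidomethyl in place of 1-aminoethyl on a carbonyl carbon). Going by the values given here, no measured pair shows this change on its own, so any forecast is loose. The closest guide is compound 3, which has no 1-aminoethyl group and still sits at its limit (> 100 ug/mL). The expected step (an at least 1.1-fold lower number from compound 1 to compound 4 (0.04 log units; that floor lies within the scatter)) is small, and any fall is expected to stay close to the usual scatter of this assay readings. For compound 4 the estimated reading is 90 ug/mL with 35 ug/mL to 200 ug/mL as the expected range.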

Compound 4, solubility: 5 ug/mL
Compound 4: the middle estimate sits 18-fold (1.26 log units) above what was measured, outside the stated range (below it).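

In this assay, swapping 1-aminoethyl for acetamidomethyl on a carbonyl carbon gives an at least 20-fold lower number from compound 1 to compound 4 (1.30 log units; beyond the scatter), a large step well beyond the usual scatter. Until this reading, the set offered no measured number to compare, so it could not show whether the group on this carbonyl carbon matters; compound 4 moves off the ceiling and shows that it can: the limit of > 100 ug/mL in this assay, at which 3 of the 4 values shown sit. The reading for compound 1 is a limit of the assay, so this step is a floor, and the true gap could be wider.

The swap changes several things at once: the entering group has more heavy atoms, brings a double bond outside aromatic rings and loses the defined stereocentre, while the counts of hydrogen-bond donors and acceptors stay the same, so these compounds cannot say which of those differences goes with the drop. From the compounds shown here alone, it also remains open where a plain aminomethyl group, a longer aminoalkyl chain or a carboxylic acid on the same carbonyl carbon would fall in this assay, and whether any of them would stay at the limit or drop as far as acetamidomethyl.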